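The compounds below may be only part of what the source reports. "The series", "measured", "known", "first", "only" and "open" are said of these compounds alone.

Measured in a functional assay on Bel-7402 cells (Homo sapiens) for cytotoxicity, read by MTT assay, with a stated time of 48 h; a lower number here means a stronger inhibitor, a higher number a weaker inhibitor:

- Compound 1 `CCn1cc(-c2nc3ccccc3[nH]2)c(=O)c2cc(F)c(N3CCNCC3)nc21`: 4100 nM
- Compound 2 `CCn1cc(-c2nc3ccccc3s2)c(=O)c2cc(F)c(N3CCNCC3)nc21`: 2400 nM

Only these two compounds have been measured, so compound 2 has a single neighbour on the scale. Compound 2 gives 2400 nM and compound 1 gives 4100 nM, two values that cannot be told apart. The next compound, compound 3 `CCn1cc(-c2nc3ccc(Cl)cc3[nH]2)c(=O)c2cc(F)c(N3CCNCC3)nc21`, has not been measured. It carries 6-chloro-1H-benzimidazol-2-yl in place of the 1,3-benzothiazol-2-yl of compound 2 on an aromatic carbon of the shared core: 6-chloro-1H-benzimidazol-2-yl in place of 1,3-benzothiazol-2-yl on an aromatic carbon.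

Among the measured compounds shown here, one measured step bears on this change: a 1.7-fold lower number from compound 1 to compound 2 (0.23 log units; within the scatter). It is the exchange of the same two parent groups, run in the opposite direction, and it is small. That points to little movement on going back to a 1H-benzimidazol-2-yl group. For the measured compounds named here, no measured compound shows what the chlorine does on its own, so the expected range has to stay wide. The expected change is a 1.2-fold higher number from compound 2 to compound 3 (0.07 log units; within the scatter), with no clear direction beyond the scatter. For compound 3 the estimated value is 2800 nM, with an expected range of 1000 nM to 7500 nM.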

Compound 3, half-maximal inhibitory concentration: 21500 nM
Beside the measured number, compound 3's estimate is 7.7-fold (0.89 log units) below it, and the stated range ends below it.
By their numbers in this assay, from the lowest: compounds 2 and 1 (each within the scatter of the next); then compound 3.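

In this assay, adding a chloro group to the 1H-benzimidazol-2-yl group gives a 5.2-fold higher number from compound 1 to compound 3 (0.72 log units; beyond the scatter) and is the only difference between these two compounds, so this single addition matters more than the parent-group exchange, which stayed within the scatter. Replacing 1,3-benzothiazol-2-yl with 6-chloro-1H-benzimidazol-2-yl gives a 9.0-fold higher number from compound 2 to compound 3 (0.95 log units; beyond the scatter) and moves compound 3 clearly toward weaker inhibition, so this group on the aromatic carbon of the shared core is not interchangeable with the two parent groups once the chlorine is present. Nothing available here accounts for this loss of cytotoxic strength.

A fluoro, methyl or methoxy group in place of the chloro would help show whether the rise belongs to chlorine itself or to any substituent on that carbon of the benzimidazole. A 6-chloro-1,3-benzothiazol-2-yl group would show whether chlorine has the same effect on the other parent group, and so whether the effect can be carried from one parent group to the other.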